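A few compounds are considered here, and "the series" means these few. Any claim that something is new, unique, unknown or untested is made for them only; others in the source may bear on it.

Compound 1 `NC/C=C(/F)COc1ccc(C(N)=O)cc1`: 1070 nM
Compound 2 `NC/C=C(/F)COc1ccc(C(=O)N2CCCC2)cc1`: 140 nM

In an assay on isolated protein for inhibition of Amine oxidase [copper-containing] 3 (Homo sapiens), read by Amplex Red (on this read-out higher numbers stand for weaker inhibition and lower numbers for stronger inhibition), compound 1 gives 1070 nM, the highest of the two numbers shown, while compound 2 gives 140 nM. Compound 3 `NC/C=C(/F)COc1ccc(C(=O)NCc2ccccc2)cc1` differs from compound 1 by benzyl in place of hydrogen on an amide-type nitrogen. Among the compounds with values here, the only measured step, a 7.6-fold lower number from compound 1 to compound 2 (0.88 log units; beyond the scatter), also replaces hydrogen on that amide-type nitrogen with a carbon group, and it lowered the number beyond the scatter. A lowering step beyond the scatter is therefore expected in this assay for compound 3 too, though benzyl is a different group from pyrrolidin-1-yl, so the size is uncertain. Compound 3 is estimated at 250 nM, within 80 nM to 800 nM, an expected step of a 4.3-fold lower number from compound 1 to compound 3 (0.63 log units; beyond the scatter).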

Compound 3, half-maximal inhibitory concentration: 80 nM
Compound 3: the middle estimate sits 3.1-fold (0.49 log units) above what was measured, within the range that was stated.
By their numbers in this assay, from the lowest: compounds 3 and 2 (each within the scatter of the next); then compound 1.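

Putting benzyl on the amide-type nitrogen gives a 13-fold lower number from compound 1 to compound 3 (1.13 log units; beyond the scatter). The number therefore falls at this position with an added six-membered aromatic ring as well, and compound 3 shows that this does not require replacing both amide hydrogens, as one remains on that nitrogen. Nothing shown here explains why the number falls.

Going by these compounds, it remains open whether the aromatic ring matters, or whether a simple methyl or a longer phenylethyl chain would serve equally. On these data alone, the effect of a carboxylic acid or an amine on the benzyl ring also remains open.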